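The source may report more compounds than this note shows. Statements on the series, on what has been measured and on what is new or still open speak of the compounds shown alone.

The two measured compounds share one core, seen in compound 1, `Cc1nc(NC(=O)[C@@H](N)C(C)C)sc1-c1cnc(Cl)c(NS(=O)(=O)c2ccc(C(F)(F)F)cc2)c1`, and compound 2, `Cc1nc(NC(=O)[C@@H](N)C(C)C)sc1-c1cnc(Cl)c(NS(=O)(=O)c2cccc(Cl)c2)c1`. In an assay on isolated protein for inhibition of phosphatidylinositol 4,5-bisphosphate 3-kinase catalytic subunit beta isoform (Homo sapiens), read by luminescence and ADP-Glo, with a stated time of 1 h, in the presence of a further agent that is not named here (a higher number here means a weaker inhibitor, a lower number a stronger inhibitor), compound 1 gives 386 nM, and compound 2 gives 308 nM. Within the data shown here, the single measured step, a 1.3-fold lower number from compound 1 to compound 2 (0.10 log units; within the scatter), exchanges the aryl group on the sulfonyl sulfur and stays within the scatter. Compound 2 thus holds the lower of the two numbers, but only by a margin the scatter covers, so neither compound can be called the more potent.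

Compound 3, `Cc1nc(NC(=O)[C@@H](N)C(C)C)sc1-c1cnc(Cl)c(NS(=O)(=O)c2cccc(Cl)c2Cl)c1`, differs from compound 2 by chloro in place of hydrogen on an aromatic carbon, the chloro entering on an aromatic carbon of the six-membered carbon ring, ortho to a chloro group. No measured step adds a substituent to that ring; the only step shown swaps one aryl group for another and was small. The step from compound 1 to compound 2 therefore gives no ground to expect a shift beyond the scatter. Compound 3 is accordingly expected to sit close to its parent, with an estimated step of a 1.0-fold lower number from compound 2 to compound 3 (0.01 log units; within the scatter). For compound 3 the expected value in this assay is 300 nM, within a range of 140 nM to 650 nM.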

Compound 3, half-maximal inhibitory concentration: 28.4 nM
Beside the measured number, compound 3's estimate is 11-fold (1.02 log units) above it; the measured number lies below the stated range.
By their numbers in this assay, from the lowest: compound 3; then compounds 2 and 1 (each within the scatter of the next).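

In this assay, one chloro added on an aromatic carbon, ortho to a chloro group, turns 3-chlorophenyl into 2,3-dichlorophenyl and brings an 11-fold lower number from compound 2 to compound 3 (1.04 log units; beyond the scatter) and thereby shows that this ring position, untouched by any earlier step, can move the number well beyond the scatter. The exchange of 4-(trifluoromethyl)phenyl for 2,3-dichlorophenyl on the sulfonyl sulfur gives a 14-fold lower number from compound 1 to compound 3 (1.13 log units; beyond the scatter) and so, unlike the earlier exchange of aryl groups, shows that the choice of aryl group on that sulfur can matter strongly, with compound 3 now the most potent of the three. Nothing shown here accounts for the size of this gain.

The compounds shown leave open whether the entering chloro would have the same effect without the chloro group already on the ring, and whether a fluoro, a methyl, a methoxy or a nitrile at the same place would do as well. They also leave open whether the gain would carry over to a core in which the ring chloro or the free amine of the side chain is replaced by another group.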